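Chalcone amides on Vero cells: from trifluoromethyl to dimethoxy

The compounds below may be only part of what the source reports. "The series", "measured", "known", "first", "only" and "open" are said of these compounds alone.

Measured so far:
- compound 1 `CC(C)Cc1ccc(C(=O)/C=C/c2ccc(C(=O)O)cc2)cc1`: < 10 ug/mL
- compound 2 `COC(=O)c1cc(-c2cccc(NC(=O)c3ccc(/C=C/C(=O)c4cccc(C(F)(F)F)c4)cc3)c2)on1`: > 20 ug/mL
- compound 3 `CCOC(=O)c1nnn(-c2cccc(NC(=O)c3ccc(/C=C/C(=O)c4ccc(Cl)cc4)cc3)c2)c1C`: "not determined" (no result reported)

The account follows compound 2 into compound 4 `COC(=O)c1cc(-c2cccc(NC(=O)c3ccc(/C=C/C(=O)c4ccc(OC)c(OC)c4)cc3)c2)on1`. In an ADME assay on Vero cells (Chlorocebus sabaeus) for cytotoxicity, read by MTT assay, with a stated time of 72 h (a higher number here means that more compound is tolerated, a lower number that less compound is tolerated), compound 2 gives only a limit, > 20 ug/mL, so its true position is not pinned to a single number. The two other entries add little to fix it: compound 1 also sits at a limit, < 10 ug/mL, and for compound 3 no result is reported, "not determined" (no result reported). Going by the values given here, the evidence therefore consists of a lower bound, (the limit of > 20 ug/mL in this assay, at which 1 of the 3 values shown sits), and an upper bound, (the limit of < 10 ug/mL in this assay, at which 1 of the 3 values shown sits), for two different compounds, with no step between measured compounds available.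

The change is 3,4-dimethoxyphenyl in place of 3-(trifluoromethyl)phenyl on a carbonyl carbon. Among the compounds with values here, no measured pair shows what this swap does in this assay. For compound 4, the expected step that the limit leaves unreadable from compound 2 to compound 4 is taken as none beyond the scatter, since nothing here points either way. The estimate for compound 4 in this assay is therefore 30 ug/mL, with a range from 12 ug/mL to 80 ug/mL, and a fair chance that again only a limit is reported.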

Compound 4, half-maximal cytotoxic concentration: > 50 ug/mL
Compound 4: a limit, no number; the forecaster's own chance of this, stated with the estimate: 60%; middle value at least 1.6-fold (0.22 log units) away from the limit.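

Going by these compounds alone, no step from compound 2 to compound 4 can be read in this assay, as each of the two compounds is reported only as a limit. The compounds shown leave open whether 3,4-dimethoxyphenyl in place of 3-(trifluoromethyl)phenyl on a carbonyl carbon changes the tolerated concentration at all, and by how much.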